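Acetyl in Place of Phenyl on the Piperazine Nitrogen

The compounds below may be only part of what the source reports. "The series", "measured", "known", "first", "only" and "open" are said of these compounds alone.

Compound 1 `Cc1ccc(-c2csc(=N)n2CC(=O)N2CCN(c3ccccc3)CC2)cc1` is one of two compounds with a result in an assay on isolated protein for inhibition of Thymidylate synthase (Homo sapiens) (on this read-out higher numbers stand for weaker inhibition and lower numbers for stronger inhibition), where compound 1 gives 5600 nM, the highest of the two numbers. Its nearest neighbour is compound 2 `CN1CCN(C(=O)Cn2c(-c3ccccc3)csc2=N)CC1`, which in this assay gives 1140 nM, a lower number than compound 1 by a margin beyond the usual scatter. For the measured compounds named here, no pair of measured compounds differs in one place only, so no single step has been observed. Compound 3 `CC(=O)N1CCN(C(=O)Cn2c(-c3ccc(C)cc3)csc2=N)CC1` has not yet been measured in this assay. It differs from compound 1 in one place: acetyl in place of phenyl on an amine nitrogen in a ring. Going by the values given here, with no measured step of this kind to lean on, the author expects a moderate move toward a lower number for compound 3, estimated as a 2.2-fold lower number from compound 1 to compound 3 (0.35 log units; beyond the scatter). The value for compound 3 in this assay is estimated at 2500 nM, within a range from 800 nM to 8000 nM.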

Compound 3, inhibition constant: 3650 nM
Compound 3: the middle estimate sits 1.5-fold (0.16 log units) below what was measured; low and high end bracket the measured number.
By their numbers in this assay, from the lowest: compound 2; then compounds 3 and 1 (each within the scatter of the next).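

Exchanging phenyl for acetyl on the amine nitrogen of the six-membered non-aromatic ring gives a 1.5-fold lower number from compound 1 to compound 3 (0.19 log units; within the scatter) in this assay, the first single step seen at this position. At this position, then, compound 3 and compound 1 read alike, although a six-membered aromatic ring of carbon only gives way to a smaller group with no ring and one hydrogen-bond acceptor. No available evidence bears on this result.

The compounds shown leave open whether a different group on this nitrogen, such as a carboxylic acid, a benzyl group or a longer chain, would move the number beyond the scatter. They also leave open whether the same exchange would read alike on a core that lacks the methyl group of compound 3.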